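Swapping a dimethoxyphenyl end for thiophene in a growth assay

The source may hold more compounds than are shown below. What is called first, only, known or untested is meant among the compounds shown, and "the series" means these compounds.

- compound 1 `COc1ccc(/C=C/C(=O)/C=C/c2ccc(OCc3cn(CCCCCOc4cc(=O)oc5ccccc45)nn3)c(OC)c2)cc1OC` gives 45%
- compound 2 `COc1cc(/C=C/C(=O)/C=C/c2ccccc2)ccc1OCc1cn(CCCCOc2cc(=O)oc3ccccc23)nn1` gives 34%
- compound 3 `COc1cccc(/C=C/C(=O)/C=C/c2ccc(OCc3cn(CCOc4cc(=O)oc5ccccc45)nn3)c(OC)c2)c1` gives 70%

These values all come from a functional assay on HCT-116 cells (Homo sapiens) for inhibition, read by sulforhodamine B assay, with a stated time of 48 h, tested at 50 uM; on this read-out higher numbers stand for more inhibition of growth at the one concentration tested and lower numbers for less inhibition of growth. Compound 1 stands in the middle of the three. Compound 2 lies lower and compound 3 lies higher, and both gaps are larger than the usual scatter between repeated measurements.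

The next compound to be tested is compound 4 `COc1cc(/C=C/C(=O)/C=C/c2cccs2)ccc1OCc1cn(CCCCCOc2cc(=O)oc3ccccc23)nn1`. It keeps the rest of compound 1 but carries thiophen-2-yl in place of 3,4-dimethoxyphenyl on a double-bonded chain carbon bound to a double-bonded chain carbon.

Going by the values given here, none of the measured compounds carries thiophen-2-yl, and no pair of them differs in only one place, so this swap has no direct precedent. The span from compound 2 at 34% to compound 3 at 70% shows only how far such compounds can move, and it offers no clear direction. The best starting point is therefore compound 1 at 45%, with no change beyond the scatter expected. The expected change is a number 3 percentage points lower from compound 1 to compound 4 (within the scatter), a small estimated drop that stays within the scatter. For compound 4 the expected value in this assay is 42%, with an estimated range from 24% to 60%.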

Compound 4, percent growth inhibition at one concentration: 31%
The estimate for compound 4 lay 11 percentage points above the measured number; the range from low to high includes it.
By their numbers in this assay, from the lowest: compounds 4 and 2 (each within the scatter of the next); then compound 1; then compound 3.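

In this assay, going by these compounds alone, exchanging 3,4-dimethoxyphenyl for thiophen-2-yl gives a number 14 percentage points lower from compound 1 to compound 4 (beyond the scatter), the first comparison here in which only one place differs, and it shows that the group at this end can shift growth inhibition at the one concentration tested. The group that leaves has 10 heavy atoms and 2 hydrogen-bond acceptors, while the group that enters has 5 heavy atoms, 1 hydrogen-bond acceptor and a sulfur in its ring, and this single step cannot separate these differences from one another. Nothing measured here bears on why the number falls.

As far as these compounds go, it remains open whether another ring at this place, such as furan-2-yl or pyridin-3-yl, would give a number closer to that of compound 1 or to that of compound 4. From the compounds shown here alone, it is also open whether the same swap would move the number in the same direction on a molecule with a shorter chain at the far end, as the step is known only with the chain that compound 1 and compound 4 share.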